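Swapping the amide aryl group for a pyridine ring

The source may report more compounds than this note shows. Statements on the series, on what has been measured and on what is new or still open speak of the compounds shown alone.

Among the measured compounds shown here, compound 2 `COc1cc2c(cc1OC)C(CC(=O)Nc1ccc(Cl)cc1)CC2` is the higher of the two compounds measured so far: in a functional assay on the whole organism (strain Wistar) for inhibition, with Rattus norvegicus as the target, read by paw edema, with a stated time of 2 h, at a dose of 100 mg/kg (a higher number here means more inhibition at the dose given (going by the name of the read-out), a lower number less inhibition), compound 2 gives 63%, whereas compound 1 `COc1cc2c(cc1OC)C(CC(=O)Nc1cccc(Cl)c1)CC2` gives 28%. For the measured compounds named here, the one measured step, a number 35 percentage points higher from compound 1 to compound 2 (beyond the scatter), shows that the aryl group on the amide nitrogen matters a great deal. Compound 3 `COc1cc2c(cc1OC)C(CC(=O)Nc1ccccn1)CC2` changes that same group again: pyridin-2-yl in place of 4-chlorophenyl on an amide-type nitrogen. Going by the values given here, no measured step involves a pyridine, so the direction cannot be read from the numbers; the only guide is that a small change there has already moved the read-out strongly, so a step beyond the scatter in either direction is plausible. The estimate for compound 3 is therefore 42% with a range from 15% to 68%, which amounts to an expected step of a number 21 percentage points lower from compound 2 to compound 3 (beyond the scatter).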

Compound 3, a percentage reported as inhibition, in the whole organism at one dose (the size of the read-out at that dose, not a potency): 32%
Compound 3: middle estimate off by 10 percentage points, on the high side; the range from low to high includes it.
By their numbers in this assay, from the lowest: compounds 1 and 3 (each within the scatter of the next); then compound 2.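

Replacing the ring on the amide-type nitrogen shows that an aromatic ring at this place does not by itself keep the read-out high: pyridin-2-yl in place of 4-chlorophenyl gives a number 31 percentage points lower from compound 2 to compound 3 (beyond the scatter) in this assay. Pyridin-2-yl in place of 3-chlorophenyl gives a number 4 percentage points higher from compound 1 to compound 3 (within the scatter), so these two groups cannot be told apart here, and among the three compounds only the 4-chlorophenyl group stands out. Nothing measured on these compounds accounts for this difference.

As far as these compounds go, it remains open how a plain phenyl ring, a 4-fluorophenyl group or a pyridin-4-yl group would read on the same nitrogen, which would help show how much of the high value of compound 2 depends on the chlorine. A saturated ring such as cyclohexyl at this place is also untested among the compounds shown.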